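The compounds below may be only part of what the source reports. "The series", "measured", "known", "first", "only" and "open" are said of these compounds alone.

Compound 1, `O=C1[C@@H](NS(=O)(=O)c2ccc(-c3ccon3)s2)CCN1Cc1cc2c[nH]ccc-2n1`, gives 17% in an assay on isolated protein for inhibition of coagulation factor X (Oryctolagus cuniculus), tested at 1 uM; a higher number here means more inhibition at the concentration tested (going by the name of the read-out), a lower number less inhibition.
Compound 2, `O=C1[C@@H](NS(=O)(=O)c2ccc(-c3ccccn3)s2)CCN1Cc1cc2c[nH]ccc-2n1`, gives 11% in this assay.

These two compounds share one core and differ only in the ring attached to the thiophene. On the numbers shown, compound 1 stands with compound 2 as its only neighbour, and the step of a number 6 percentage points lower from compound 1 to compound 2 (within the scatter) between them is a difference that sits within the usual scatter, so the two read-outs cannot be told apart.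

Compound 3, `O=C1[C@@H](NS(=O)(=O)c2cc3cccnc3s2)CCN1Cc1cc2c[nH]ccc-2n1`, has not yet been measured in this assay. Relative to compound 1 the change is a group of 9 heavy atoms (7 carbon, 1 nitrogen, 1 sulfur; one five-membered aromatic ring with 1 hetero atom, one six-membered aromatic ring with 1 hetero atom) in place of a group of 10 heavy atoms (7 carbon, 1 nitrogen, 1 oxygen, 1 sulfur; one five-membered aromatic ring with 1 hetero atom, one five-membered aromatic ring with 2 hetero atoms), on a sulfonyl sulfur. Among the measured compounds shown here, the one measured step that bears on this position, a number 6 percentage points lower from compound 1 to compound 2 (within the scatter), swapped one ring for another on the same thiophene and did not move the read-out beyond the scatter. That single step is a weak guide: it replaces a ring rather than fusing one. Still, nothing in the data points to a large move in either direction.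

Compound 3 is therefore expected to show a step of about a number 3 percentage points lower from compound 1 to compound 3 (within the scatter), that is, no change beyond the scatter.

Compound 3 is estimated at 14%, within a range of 2% to 30%.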

Compound 3, a percentage reported as inhibition, at one concentration (the size of the read-out at that concentration, not a potency): 18%
Beside the measured number, compound 3's estimate is 4 percentage points below it; measured number inside the range.
By their numbers in this assay, from the lowest: compounds 2, 1 and 3 (each within the scatter of the next).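

In this assay, the step of a number 1 percentage points higher from compound 1 to compound 3 (within the scatter) shows that the whole group on the sulfonyl sulfur can be exchanged, and not only its outer ring as in the earlier step, without the read-out moving beyond the usual scatter. The 5-(1,2-oxazol-3-yl)thiophen-2-yl group gives way to one with a five-membered and a six-membered aromatic ring, and compound 3 gives 18%, so inhibition at the tested concentration stays partial with either group. No measurement offered here explains why this exchange leaves the read-out within the scatter.

All the compounds shown carry two aromatic rings in the group on the sulfonyl sulfur, so it remains open what a single ring with a chlorine atom, a plain alkyl chain or a group bearing an amine would do at this position. The shared core also stays the same throughout, and a single-concentration percentage like this one gives the size of the inhibition at that concentration, not a potency.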